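The source may report more compounds than this note shows. Statements on the series, on what has been measured and on what is new or still open speak of the compounds shown alone.

In a functional assay (Homo sapiens) (a higher number here means a weaker inhibitor, a lower number a stronger inhibitor), compound 1 (`Nc1nc2ccnc(-c3cccc(OC(F)F)c3)n2n1`) gives 3400 nM; 3400 nM (2 entries), and compound 2 (`CCOC(=O)c1cccc(-c2nccc3nc(N)nn23)c1`) gives 11500 nM, the higher of the two values. Compound 3 (`Nc1nc2ccnc(-c3cccc(Cl)c3)n2n1`) differs from compound 2 in one place, with chloro in place of ethoxycarbonyl on an aromatic carbon. Among the compounds with values here, no step between measured compounds is available, and the only guide is compound 1 at 3400 nM; 3400 nM (2 entries), so the value is expected to fall. The estimated move in this assay is moderate, a 3.3-fold lower number from compound 2 to compound 3 (0.52 log units; beyond the scatter). For compound 3 the expected value is 3500 nM, with an estimated range of 900 nM to 12000 nM.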

Compound 3, half-maximal inhibitory concentration: 4300 nM
Estimate against measurement, compound 3: 1.2-fold (0.09 log units) below; measured number inside the range.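

At this position, on an aromatic carbon of a six-membered aromatic ring of carbon only, chloro in place of ethoxycarbonyl gives a 2.7-fold lower number from compound 2 to compound 3 (0.43 log units; beyond the scatter) in this assay. This shows that the number responds to the group placed here, and that the five heavy atoms of ethoxycarbonyl are not required for activity, since compound 3 with one chlorine atom reads 4300 nM. Nothing at hand accounts for the step. On these data alone, whether the carbonyl or the ethyl part of the ester drives the difference stays open. So does how an amine or a carboxylic acid at this position would compare.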